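This account rests on a few compounds, and the source may have more. Where it says the series, first, only, none or still open, it means among the compounds named here.

Working notes on the series.

Compound 1 `CCCCCCCC(=O)Nc1nnc(S[C@@H]2O[C@H](CO)[C@H](O)[C@H](O)[C@H]2O)s1` and compound 2 `CCCCCCCCCCCCCCCC(=O)Nc1nnc(S[C@@H]2O[C@H](CO)[C@H](O)[C@H](O)[C@H]2O)s1` share one core; compound 3 `CCCCCCCCCCCCCCCCCC(=O)Nc1nnc(S[C@@H]2O[C@H](COC(C)=O)[C@H](OC(C)=O)[C@H](OC(C)=O)[C@H]2OC(C)=O)s1` carries a second core, and the difference between the two cores is not broken down here. In a functional assay on MDA-MB-231 cells (Homo sapiens) for cytotoxicity, read by MTT assay, with a stated time of 24 h (a lower number here means a stronger inhibitor, a higher number a weaker inhibitor), compound 1 gives 30800 nM, compound 2 gives 62300 nM and compound 3 gives 23600 nM. Compound 3 stands at the lowest of the three numbers; its gap to compound 1 is within the scatter, its gap to compound 2 lies beyond it.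

For the measured compounds named here, the one counted step is the pair compound 2 to compound 1, (hydrogen in place of octyl on a saturated chain carbon, seven bonds along the chain from a carbonyl carbon), which in this assay gave a 2.0-fold lower number from compound 2 to compound 1 (0.31 log units; beyond the scatter), a modest step.

Compound 4 `CCCCCCCCCC(=O)Nc1nnc(S[C@@H]2O[C@H](COC(C)=O)[C@H](OC(C)=O)[C@H](OC(C)=O)[C@H]2OC(C)=O)s1` is not yet measured. It differs from compound 3 by hydrogen in place of octyl on a saturated chain carbon, nine bonds along the chain from a carbonyl carbon. Going by the values given here, this is the same kind of change as the one from compound 2 to compound 1, not the same: there the place is seven bonds along the chain from a carbonyl carbon, here it is nine bonds along the chain from a carbonyl carbon, and the core is the other one.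

Among the compounds with values here, since the change from compound 2 to compound 1 gave a 2.0-fold lower number from compound 2 to compound 1 (0.31 log units; beyond the scatter), a step of similar direction and size is expected in this assay for compound 4, namely a 1.7-fold lower number from compound 3 to compound 4 (0.23 log units; within the scatter), with the caveat that only one such step has been seen and on a different core. Compound 4 is therefore estimated at 14000 nM, within a range of 6000 nM to 35000 nM.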

Compound 4, half-maximal inhibitory concentration: 19200 nM
The estimate for compound 4 lay 1.4-fold (0.14 log units) below the measured number; low and high end bracket the measured number.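

On the core of the acetylated compounds, hydrogen in place of octyl, nine bonds along the chain from a carbonyl carbon, gives in this assay a 1.2-fold lower number from compound 3 to compound 4 (0.09 log units; within the scatter), so this step on its own does not separate the two compounds. Set beside the earlier step on the other core, the new step cannot be told apart from it: the same change on two cores in this assay, a 2.0-fold lower number (0.31 log units; beyond the scatter) from compound 2 to compound 1 and a 1.2-fold lower number (0.09 log units; within the scatter) from compound 3 to compound 4, 1.6-fold (0.22 log units) apart, within the scatter of two such steps. For the compounds shown here, this shows that nothing so far speaks against carrying the change from one core to the other, but it does not show that the change carries over with the same size, since each core offers a single pair, the place on the chain differs between the two pairs, and only the step on the first core lies beyond the scatter.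

The compounds shown leave open how the two cores compare at a fixed chain, as no one chain appears on both, so the core difference and the chain difference stay unresolved in any comparison across cores. Also open, as far as these compounds go, is what a chain ending in an amine or a carboxylic acid, or a branched chain, would do in this assay on either core.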